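Two Esters, One Modest Step, One Open Question

The compounds below may be only part of what the source reports. "The series", "measured", "known", "first", "only" and "open" are said of these compounds alone.

Compound 1 `CC(=O)O[C@H]1CC[C@]2(C)[C@H](CC[C@@](C)(O)[C@H]2CC[C@@H]2C(C)=CC[C@@H]3C(C)=CC[C@@H]3C2(C)C)OC1(C)C` - 39200 nM
Compound 2 `CC1=CC[C@H]2[C@@H]1CC=C(C)[C@@H](CC[C@H]1[C@]3(C)CC[C@H](OC(=O)c4ccncc4)C(C)(C)O[C@H]3CC[C@@]1(C)O)C2(C)C` - 19100 nM

Among the measured compounds shown here, in a functional assay on MDA-MB-231 cells (Homo sapiens) for antiproliferative activity, read by MTT assay, with a stated time of 72 h (on this read-out lower numbers stand for stronger inhibition and higher numbers for weaker inhibition), compound 2 gives 19100 nM and holds the lower of the two numbers so far, while its only neighbour, compound 1, stands at 39200 nM on the same scale.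

The next compound, compound 3 `CC1=CC[C@H]2[C@@H]1CC=C(C)[C@@H](CC[C@H]1[C@]3(C)CC[C@H](OC(=O)c4ccc(Cl)cc4)C(C)(C)O[C@H]3CC[C@@]1(C)O)C2(C)C`, has not yet been measured. It differs from compound 2 by 4-chlorophenyl in place of pyridin-4-yl on a carbonyl carbon, which means 4-chlorophenyl in place of pyridin-4-yl on a carbonyl carbon, with the shared core unchanged.

For the measured compounds named here, one measured step bears on this place, a 2.1-fold lower number from compound 1 to compound 2 (0.31 log units; beyond the scatter), where pyridin-4-yl replaced methyl on the same carbonyl carbon. Going by the values given here, that step was modest, and no measured step shows what swapping one six-membered aromatic ring for the other does. A large move is therefore not expected in this assay, and no clear direction can be argued.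

The step expected is a 1.1-fold lower number from compound 2 to compound 3 (0.05 log units; within the scatter), which would leave the two compounds much alike. The estimated value for compound 3 is 17000 nM, with an expected range from 7000 nM to 40000 nM for the measurement.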

Compound 3, half-maximal inhibitory concentration: 12700 nM
For compound 3 the middle estimate is 1.3-fold (0.13 log units) above the measured one; measured number inside the range.
By their numbers in this assay, from the lowest: compounds 3 and 2 (each within the scatter of the next); then compound 1.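

Compound 3 shows that the kind of aromatic ring on this carbonyl carbon makes no readable difference here: in this assay, 4-chlorophenyl in place of pyridin-4-yl gives a 1.5-fold lower number from compound 2 to compound 3 (0.18 log units; within the scatter), so compound 2 and compound 3 stand level within the scatter. The comparison with methyl on the same carbon gives a second reading, with 4-chlorophenyl in place of methyl giving a 3.1-fold lower number from compound 1 to compound 3 (0.49 log units; beyond the scatter), a modest step beyond the scatter; among these three compounds, both aromatic rings therefore stand apart from methyl, and no compound goes against this. No measurement at hand accounts for these numbers.

On these data alone, what remains open is how far this pattern extends at the same carbonyl carbon, for instance whether an amine-bearing chain, a carboxylic acid or a longer alkyl chain in place of the ring would keep, lose or extend the modest step seen from methyl. The three compounds also leave open whether pyridin-4-yl and 4-chlorophenyl would stay level in any other assay or with any change elsewhere on the shared core.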